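A few compounds are considered here, and "the series" means these few. Any claim that something is new, unique, unknown or untested is made for them only; others in the source may bear on it.

Going by the values given here, compound 2 `O=C1NCCN1c1ccc(S(=O)(=O)Nc2ccc(I)cc2)cc1` carries a 4-iodophenyl on a sulfonamide nitrogen, and in a functional assay on MCF7 cells (Homo sapiens) for antiproliferative activity, read by sulforhodamine B assay, with a stated time of 48 h (on this read-out lower numbers stand for stronger inhibition and higher numbers for weaker inhibition), compound 2 gives 600 nM, the highest of the two numbers known. Compound 1 `Cc1ccccc1NS(=O)(=O)c1ccc(N2CCNC2=O)cc1` gives 280 nM, and the step of a 2.1-fold higher number from compound 1 to compound 2 (0.33 log units; beyond the scatter) separates them. Compound 3 `CC(C)(C)c1ccc(NS(=O)(=O)c2ccc(N3CCNC3=O)cc2)cc1` reaches only a limit of this assay, > 1000 nM. Because of the limit of > 1000 nM in this assay, at which 1 of the 3 values shown sits, the step of an at least 1.6-fold higher number from compound 2 to compound 3 (0.22 log units; that floor lies within the scatter) tells little. Compound 4 `Cc1ccc(NS(=O)(=O)c2ccc(N3CCNC3=O)cc2)cc1C` differs from compound 2 in one place: 3,4-dimethylphenyl in place of 4-iodophenyl on a sulfonamide nitrogen. The entering group returns toward the methyl-bearing aryl of compound 1, whose value is 280 nM, so a somewhat lower number is expected for compound 4, though likely not beyond the scatter. The expected step is a 1.7-fold lower number from compound 2 to compound 4 (0.23 log units; within the scatter), and compound 4 is estimated at 350 nM, ranging from 150 nM to 800 nM.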

Compound 4, half-maximal inhibitory concentration: 230 nM
Beside the measured number, compound 4's estimate is 1.5-fold (0.18 log units) above it; the measured number falls inside the stated range.
By their numbers in this assay, from the lowest: compounds 4 and 1 (each within the scatter of the next); then compound 2. At a limit, above all of these: compound 3.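

In this assay, 3,4-dimethylphenyl in place of 4-iodophenyl on the sulfonamide nitrogen gives a 2.6-fold lower number from compound 2 to compound 4 (0.42 log units; beyond the scatter). Set against 2-methylphenyl, the same group gives a 1.2-fold lower number from compound 1 to compound 4 (0.09 log units; within the scatter), so the two methyl-bearing aryl groups cannot be told apart here, while each stands apart from the iodo-bearing aryl of compound 2. Compound 3 cannot be placed in this order: the limit of > 1000 nM in this assay, at which 1 of the 4 values shown sits.

From the compounds shown here alone, what remains open is how an aryl carrying a methoxy group, an amine or a carboxylic acid at this nitrogen would compare. The compounds shown also leave open whether a plain phenyl would stand with the methyl-bearing groups.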